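The source may hold more compounds than are shown below. What is called first, only, known or untested is meant among the compounds shown, and "the series" means these compounds.

Measured compounds in a physicochemical assay for solubility, read by HPLC, with a stated time of 24 h; a higher number here means a more soluble compound, a lower number a less soluble compound:
Compound 1 `O=C1CSC(=O)N1C[C@H]1CN(c2ccc(-n3cc(-c4ccccn4)cn3)c(F)c2)C(=O)O1`: 26900 nM
Compound 2 `CC(=O)OC[C@H]1CN(c2ccc(-n3cc(-c4ccccn4)cn3)c(F)c2)C(=O)O1`: 373000 nM

Compound 2 stands highest of the two numbers; its nearest neighbour is compound 1, and the step runs a 14-fold higher number from compound 1 to compound 2 (1.14 log units; beyond the scatter) for acetoxy in place of 2,4-dioxo-1,3-thiazolidin-3-yl on a saturated chain carbon bound to a saturated ring carbon.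

Compound 3 `O=C(OC[C@H]1CN(c2ccc(-n3cc(-c4ccccn4)cn3)c(F)c2)C(=O)O1)c1ccccc1` has not been measured in this assay. It differs from compound 2 by phenyl in place of methyl on a carbonyl carbon whose other neighbour is oxygen next to a carbonyl group; read one bond further out, acetoxy becomes benzoyloxy. For the measured compounds named here, no measured step bears directly on this change: the only step seen, from compound 1 to compound 2, exchanges the whole group at the chain end rather than the acyl substituent, so it offers no guide to its size. With the ester kept and a larger acyl group entering, a modest fall in this assay is expected, of size a 3.1-fold lower number from compound 2 to compound 3 (0.49 log units; beyond the scatter), possibly not beyond the scatter. Compound 3 is therefore estimated at 120000 nM, with a range from 40000 nM to 300000 nM.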

Compound 3, solubility: <= 65400 nM
Compound 3 was reported as a limit (the forecaster's own chance of this, stated with the estimate: 5%); middle value at least 1.8-fold (0.26 log units) away from the limit.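

In this assay, the read-out at this position responds to the acyl substituent alone, and not only to exchange of the whole group at the chain end: with the ester kept, phenyl in place of methyl on a carbonyl carbon gives an at least 5.7-fold lower number from compound 2 to compound 3 (0.75 log units; beyond the scatter). Compound 3 stands at <= 65400 nM, which is a limit of the assay and not a number. The step from compound 1 to compound 3 cannot be read, so benzoyloxy and 2,4-dioxo-1,3-thiazolidin-3-yl remain unordered in this series: the limit of <= 65400 nM in this assay, at which 1 of the 3 values shown sits.

From the compounds shown here alone, the actual number for compound 3 stays open, and with it the full size of the change from methyl to phenyl. Also open, going by these compounds, is whether a longer chain in place of methyl, or a phenyl carrying an amine or a carboxylic acid, would move the read-out in the same direction.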